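The compounds below may be only part of what the source reports. "The series", "measured", "known", "first", "only" and "open" are said of these compounds alone.

Four compounds are compared here. Compound 1 `O=C(O)CC1Cc2ccc(-c3cc(F)cc(OC(F)F)c3)cc2N1S(=O)(=O)c1cccc(C(F)(F)F)c1` and compound 2 `O=C(O)CCC1Cc2ccc(-c3cc(F)cc(OC(F)F)c3)cc2N1S(=O)(=O)c1cccc(C(F)(F)F)c1` share one core, while compound 3 `O=C(O)CC1CN(S(=O)(=O)c2cccc(C(F)(F)F)c2)c2cc(-c3cc(F)cc(OC(F)F)c3)ccc21` and compound 4 `O=C(O)CCC1CN(S(=O)(=O)c2cccc(C(F)(F)F)c2)c2cc(-c3cc(F)cc(OC(F)F)c3)ccc21` share another. The two cores hold the same atoms joined differently, and the difference between them is not broken down here. Within each core the same change is made once: compound 2 differs from compound 1 by carboxymethyl in place of carboxy on a saturated chain carbon bound to a saturated ring carbon, and compound 4 differs from compound 3 by carboxymethyl in place of carboxy on a saturated chain carbon bound to a saturated ring carbon, at the same place in both pairs.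

In an ADME assay on microsomes from liver (Mus musculus) for metabolic stability, read by LC-MS, using NADPH, with a stated time of 60 min, tested at 1 uM (on this read-out lower numbers stand for a shorter-lived compound and higher numbers for a longer-lived compound), compound 1 gives 1.88 h, compound 2 gives 1.02 h and compound 3 gives 0.76 h. The change within the first core produced a 1.8-fold lower number from compound 1 to compound 2 (0.27 log units; within the scatter). The value of compound 3 lies beyond the scatter below that of compound 1, but within the scatter of that of compound 2, so those two are not told apart.

Among the measured compounds shown here, compound 4 carries the same change as compound 2, on a different core, and the only guide for it is the one measured step. The expected step is a 1.8-fold lower number from compound 3 to compound 4 (0.26 log units; within the scatter), because the same change once gave a 1.8-fold lower number from compound 1 to compound 2 (0.27 log units; within the scatter). Compound 4 is therefore expected to show about 0.42 h, estimated to fall between 0.22 h and 0.85 h. Whether the second core carries the change in the same way is what the measurement of compound 4 will show.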

Compound 4, half-life: 0.408 h
Beside the measured number, compound 4's estimate is 1.0-fold (0.01 log units) above it, and the stated range covers the measured number.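

In this assay, putting carboxymethyl in place of carboxy on the second core gives a 1.9-fold lower number from compound 3 to compound 4 (0.27 log units; within the scatter), and this step can be set directly beside the same change on the first core: the same change on two cores in this assay, a 1.8-fold lower number (0.27 log units; within the scatter) from compound 1 to compound 2 and a 1.9-fold lower number (0.27 log units; within the scatter) from compound 3 to compound 4, 1.0-fold (0.00 log units) apart, within the scatter of two such steps. Within these four compounds, then, the change carries from one core to the other with a step of matching size, so the step measured on one core was a fair guide to the step on the other. This does not show that the change has a real effect on half-life, since each step taken alone lies within the scatter, nor does it show why the two steps match, and two pairs cannot establish a rule for other cores in the series.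

The compounds shown stop at the 2-carboxyethyl chain, so it remains open whether a longer chain at the same place would continue along the same lines on both cores. As far as these compounds go, it also remains open whether an amide or a tetrazole in place of the carboxylic acid would give matching steps on the two cores, or whether a third core would follow these two.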